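Swapping one aryl group on a weak carboxy compound

The source may report more compounds than this note shows. Statements on the series, on what has been measured and on what is new or still open speak of the compounds shown alone.

Values in a functional assay on DU-145 cells (Homo sapiens) for inhibition, read by trypan blue exclusion, with a stated time of 96 h; a lower number here means a stronger inhibitor of growth, a higher number a weaker inhibitor of growth:
compound 1 `O=C(O)c1ccc(C(=O)/C(=C\c2ccc(Br)cc2)SCc2ccc(F)cc2)cc1`: > 100000 nM
compound 2 `O=C(/C(=C\c1ccc(Br)cc1)SCc1ccc(F)cc1)c1ccc(Br)cc1`: 25000 nM
compound 3 `O=C(/C(=C\c1ccc(Br)cc1)SCc1ccc(F)cc1)c1ccc(Cl)cc1`: 9000 nM

Compound 1 has no exact number, only a limit: the limit of > 100000 nM in this assay, at which 1 of the 3 values shown sits. Among these three, compound 1 is the weakest inhibitor of growth.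

Compound 4 `COc1ccc(/C=C(/SCc2ccc(F)cc2)C(=O)c2ccc(C(=O)O)cc2)cc1O` keeps the carboxy group of compound 1 but carries 3-hydroxy-4-methoxyphenyl in place of 4-bromophenyl on a double-bonded chain carbon bound to a double-bonded chain carbon. Going by the values given here, compounds 1, 2 and 3 all carry 4-bromophenyl, so no measured step tests this swap directly. The steps of an at least 4.0-fold lower number from compound 1 to compound 2 (0.60 log units; beyond the scatter) and an at least 11-fold lower number from compound 1 to compound 3 (1.04 log units; beyond the scatter), at least modest and large, both remove the carboxy group. The step of a 2.8-fold lower number from compound 2 to compound 3 (0.44 log units; beyond the scatter) is a modest exchange of one halogen for another. These steps show that a single change can move the number beyond the scatter. Compound 4 retains the carboxy group whose replacement gave an at least 11-fold lower number from compound 1 to compound 3 (1.04 log units; beyond the scatter), so it is expected to stay fairly weak, and another limit is possible. The change is expected to be an at least 3.3-fold lower number from compound 1 to compound 4 (0.52 log units; beyond the scatter), and this estimate is very uncertain. For compound 4 the estimated value is 30000 nM, with an expected range of 2000 nM to 100000 nM.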

Compound 4, concentration for 50% growth inhibition: 10000 nM
Compound 4: the middle estimate sits 3.0-fold (0.48 log units) above what was measured, and the stated range covers the measured number.
By their numbers in this assay, from the lowest: compounds 3 and 4 (each within the scatter of the next); then compound 2. At a limit, above all of these: compound 1.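

In this assay, the aryl group on the double-bonded chain carbon can move the number even with the carboxy group kept: 3-hydroxy-4-methoxyphenyl in place of 4-bromophenyl gives an at least 10-fold lower number from compound 1 to compound 4 (1.00 log units; beyond the scatter). Going by these compounds alone, the earlier steps all changed the other aryl group, the one carrying the carboxy group or a halogen, so this is the first reading at this place, and it shows that keeping the carboxy group does not by itself fix a compound at the weak end. Compound 1 stands at a limit and not at a number: the limit of > 100000 nM in this assay, at which 1 of the 4 values shown sits.

From the compounds shown here alone, the hydroxy and the methoxy enter together, so what each contributes alone stays open. Also open, going by these compounds, are what a group carrying an amine would do at this place, and whether 3-hydroxy-4-methoxyphenyl gives a similar step when bromo or chloro replaces the carboxy group.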